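Notes on adding methoxy to compound 2

The source may report more compounds than this note shows. Statements on the series, on what has been measured and on what is new or still open speak of the compounds shown alone.

Values in an ADME assay on KB cells (Homo sapiens) for cytotoxicity, read by MTT assay, with a stated time of 72 h; a higher number here means that more compound is tolerated, a lower number that less compound is tolerated:
- Compound 1 `COc1ccc(-c2csc(Nc3ccc(Cl)cn3)n2)nc1` gives 59600 nM
- Compound 2 `Clc1ccc(Nc2nc(-c3ccccn3)c(Cl)s2)nc1` gives 326000 nM

Compound 2 stands highest of the two, beyond the scatter from compound 1. Compound 3 `COc1ccc(-c2nc(Nc3ccc(Cl)cn3)sc2Cl)nc1` carries methoxy in place of hydrogen on an aromatic carbon of compound 2 (methoxy in place of hydrogen on an aromatic carbon). For the measured compounds named here, no measured pair isolates this change. Compound 1 carries the methoxy and gives 59600 nM, but it also differs from compound 2 elsewhere, so only the direction is suggested. A fall in this assay beyond the scatter is expected, with the estimated step of a 2.7-fold lower number from compound 2 to compound 3 (0.43 log units; beyond the scatter). The estimate for compound 3 is 120000 nM, with an expected range of 40000 nM to 350000 nM.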

Compound 3, half-maximal cytotoxic concentration: 248000 nM
Beside the measured number, compound 3's estimate is 2.1-fold (0.32 log units) below it; the range from low to high includes it.
By their numbers in this assay, from the lowest: compound 1; then compounds 3 and 2 (each within the scatter of the next).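

In this assay methoxy in place of hydrogen on an aromatic carbon, two atoms from the ring nitrogen and para to a large group, gives a 1.3-fold lower number from compound 2 to compound 3 (0.12 log units; within the scatter) and so cannot be told apart from hydrogen in this pair. For the compounds shown here, with the methoxy present, chloro in place of hydrogen on an aromatic carbon gives a 4.2-fold higher number from compound 1 to compound 3 (0.62 log units; beyond the scatter) as the one step here beyond the scatter. No measured evidence bears on why these two steps came out this way. On these data alone, whether an amine or a longer chain such as ethoxy at the methoxy position would stay within the scatter of compound 2 remains open. Also open, as far as these compounds go, is what methoxy does in a compound lacking the chloro.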